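A few compounds are considered here, and "the series" means these few. Any claim that something is new, unique, unknown or untested is made for them only; others in the source may bear on it.

Measured so far in an assay on isolated protein for inhibition of coagulation factor X (Oryctolagus cuniculus), tested at 1 uM; a lower number here means less inhibition, a higher number more inhibition at the concentration tested (going by the name of the read-out):

compound 1, `O=C1[C@@H](NS(=O)(=O)c2ccc(-c3ccccn3)s2)CCN1Cc1cc2c[nH]ccc-2n1`, gives 11%
compound 2, `O=C1[C@@H](NS(=O)(=O)c2ccc(-c3ccccn3)s2)CCN1Cc1cc2cc[nH]cc-2n1`, gives 17%
compound 3, `Cc1c(S(=O)(=O)N[C@H]2CCN(Cc3cc4c[nH]ccc-4n3)C2=O)sc2ccc(Cl)cc12`, gives 37%

Compounds 1 and 2 share the same core and differ only in the group on the saturated chain carbon bound to the amide-type nitrogen in the ring: a group of 9 heavy atoms (7 carbon, 2 nitrogen; one five-membered aromatic ring with 1 hetero atom, one six-membered aromatic ring with 1 hetero atom) in place of a group of 9 heavy atoms (7 carbon, 2 nitrogen; one five-membered aromatic ring with 1 hetero atom, one six-membered aromatic ring with 1 hetero atom), on a saturated chain carbon bound to an amide-type nitrogen in a ring. The step this made was a number 6 percentage points higher from compound 1 to compound 2 (within the scatter), so the two numbers cannot be told apart. Compound 3 stands on a different core; the difference between the two cores is not broken down here. Compound 3 holds the highest number of the three, and its gaps to compound 2 and to compound 1 both lie beyond the scatter.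

Compound 4, `Cc1c(S(=O)(=O)N[C@H]2CCN(Cc3cc4cc[nH]cc-4n3)C2=O)sc2ccc(Cl)cc12`, is not yet measured. It differs from compound 3 by a group of 9 heavy atoms (7 carbon, 2 nitrogen; one five-membered aromatic ring with 1 hetero atom, one six-membered aromatic ring with 1 hetero atom) in place of a group of 9 heavy atoms (7 carbon, 2 nitrogen; one five-membered aromatic ring with 1 hetero atom, one six-membered aromatic ring with 1 hetero atom), on a saturated chain carbon bound to an amide-type nitrogen in a ring, the same change as from compound 1 to compound 2, at the same place. Going by the values given here, the step expected is a number 5 percentage points higher from compound 3 to compound 4 (within the scatter), resting on the single earlier instance a number 6 percentage points higher from compound 1 to compound 2 (within the scatter), which was seen on one core only. Compound 4 is expected to give 42% in this assay. The expected range for compound 4 runs from 28% to 56%.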

Compound 4, a percentage reported as inhibition, at one concentration (the size of the read-out at that concentration, not a potency): 52%
The estimate for compound 4 lay 10 percentage points below the measured number; low and high end bracket the measured number.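

In this assay the change gives a number 15 percentage points higher from compound 3 to compound 4 (beyond the scatter) on the core of compound 3. The two cores do not give steps that can be told apart, so the change carries from one core to the other without a measurable difference in its size: the same change on two cores in this assay, a number 6 percentage points higher (within the scatter) from compound 1 to compound 2 and a number 15 percentage points higher (beyond the scatter) from compound 3 to compound 4, 9 percentage points apart, within the scatter of two such steps
Going by these compounds alone, this does not establish a general transfer: it rests on two cores, only one of the two steps lies beyond the scatter, and a reading at a single concentration is not a potency.

The compounds shown leave open whether the step would hold on a core carrying an amine or a carboxylic acid in place of the chlorine of compound 3. Also open, from the compounds shown here alone, is whether the same change would hold with a longer chain in place of the single saturated carbon that carries the group, on either core.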